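Removing the ring halogen from compound 2: expectation for compound 3

This account rests on a few compounds, and the source may have more. Where it says the series, first, only, none or still open, it means among the compounds named here.

Measured compounds in an ADME assay on CCRF-CEM cells (Homo sapiens) for cytotoxicity, with a stated time of 72 h; a lower number here means a stronger inhibitor, a higher number a weaker inhibitor:
- compound 1 `O=Cc1c(-c2ccc(Cl)cc2)nc2sc(Cc3ccc(Cl)cc3)nn12`: 5800 nM
- compound 2 `O=Cc1c(-c2ccc(Br)cc2)nc2sc(Cc3ccc(Cl)cc3)nn12`: 4000 nM

Within the data shown here, compound 2 carries the lower of the two numbers, but the only measured step, a 1.5-fold lower number from compound 1 to compound 2 (0.16 log units; within the scatter), lies within the scatter, so the two compounds are not separated in this assay.

Compound 3 `O=Cc1c(-c2ccccc2)nc2sc(Cc3ccc(Cl)cc3)nn12` is the next member. Against compound 2 the change is hydrogen in place of bromo on an aromatic carbon; read one bond further out, 4-bromophenyl becomes phenyl, the rest of the shared core being unchanged.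

Among the measured compounds shown here, only one measured step bears on this, the halogen swap from compound 1 to compound 2, and that step is within the scatter. For the measured compounds named here, no measured pair removes a halogen from this ring altogether, so the series gives no direct guide for the size or direction of the present step. The working expectation is therefore a modest step, if any, estimated as a 1.8-fold higher number from compound 2 to compound 3 (0.24 log units; within the scatter) in this assay, with a wide range to reflect the lack of a precedent.

For compound 3 the estimate in this assay is 7000 nM, expected between 3000 nM and 18000 nM.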

Compound 3, half-maximal inhibitory concentration: 22000 nM
Beside the measured number, compound 3's estimate is 3.1-fold (0.50 log units) below it, and the stated range ends below it.
By their numbers in this assay, from the lowest: compounds 2 and 1 (each within the scatter of the next); then compound 3.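

In this assay, this position responds to losing its halogen: replacing bromo with hydrogen gives a 5.5-fold higher number from compound 2 to compound 3 (0.74 log units; beyond the scatter), and replacing chloro with hydrogen gives a 3.8-fold higher number from compound 1 to compound 3 (0.58 log units; beyond the scatter), whereas the exchange of one halogen for the other gave only a 1.5-fold lower number from compound 1 to compound 2 (0.16 log units; within the scatter). Across these three compounds, the separation therefore lies between a halogen and hydrogen on the aromatic carbon para to a large group, and not between chloro and bromo, since compound 1 and compound 2 remain unseparated while compound 3 stands apart from both. No measurement is available that accounts for this step.

On these data alone, it remains open whether the halogens are special here or whether other groups on the same carbon, such as fluoro, methyl, methoxy or an amine, would keep the number close to those of compound 1 and compound 2 or leave it nearer that of compound 3. As far as these compounds go, all three compounds share the rest of their structure, so it is also open whether the step would keep its size with a change elsewhere on the shared core.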